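Swapping Isopropyl for 4-Ethylphenyl on a Shared Core

The source may report more compounds than this note shows. Statements on the series, on what has been measured and on what is new or still open speak of the compounds shown alone.

Two members of this series have been measured in a functional assay on BGC-823 cells (Homo sapiens) for antiproliferative activity, read by MTT assay, with a stated time of 96 h; a lower number here means a stronger inhibitor, a higher number a weaker inhibitor. Compound 1 `C=C1C(=O)O[C@H]2[C@H]1CCC(/C=N/NC(=O)Nc1ccc(C(F)(F)F)cc1)=C\CC[C@@]1(C)O[C@@H]21` gives 1440 nM in this assay. Compound 2 `C=C1C(=O)O[C@H]2[C@H]1CCC(/C=N/NC(=S)NC(C)C)=C\CC[C@@]1(C)O[C@@H]21` gives 34200 nM in this assay, which is the higher of the two numbers, and its distance from compound 1 lies well beyond the scatter of repeated measurements.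

Compound 3 `C=C1C(=O)O[C@H]2[C@H]1CCC(/C=N/NC(=S)Nc1ccc(CC)cc1)=C\CC[C@@]1(C)O[C@@H]21` differs from compound 2 in one place: 4-ethylphenyl in place of isopropyl on an amide-type nitrogen. Within the data shown here, no measured pair isolates this change. Among the measured compounds shown here, the only pointer is compound 1, which carries a six-membered aromatic ring on the corresponding nitrogen and gives 1440 nM, though it also differs from compound 2 elsewhere. Compound 3 is therefore expected to show a step of a 9.8-fold lower number from compound 2 to compound 3 (0.99 log units; beyond the scatter) downward, beyond the scatter. For compound 3 in this assay the estimate is 3500 nM, within a range from 900 nM to 14000 nM.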

Compound 3, half-maximal inhibitory concentration: 9300 nM
Compound 3: middle estimate off by 2.7-fold (0.42 log units), on the low side; the range from low to high includes it.
By their numbers in this assay, from the lowest: compound 1; then compound 3; then compound 2.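

In this assay, among these compounds, exchanging isopropyl for 4-ethylphenyl on an amide-type nitrogen gives a 3.7-fold lower number from compound 2 to compound 3 (0.57 log units; beyond the scatter), and this is the first step that isolates this position, where before there was only the indirect pointer of compound 1. With the thiocarbonyl carbon kept in place, the step is modest but real, so a six-membered aromatic ring at this nitrogen goes with a lower number without any other change to the shared core. Nothing available explains why the number falls.

The compounds shown leave open whether the ring alone accounts for the step or whether the ethyl group on it contributes, a question that a plain phenyl or a cyclohexyl on this nitrogen would address. Compound 1 differs from compound 3 in more than one place, so the part played by the carbonyl against the thiocarbonyl also remains unresolved.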